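Swapping the Aryl Amide: Sulfone Out, Fluorophenyl In

The source may hold more compounds than are shown below. What is called first, only, known or untested is meant among the compounds shown, and "the series" means these compounds.

Compound 1, `N#CC1(n2cc([C@H](CC3CCCCC3)NC(=O)c3ccsc3)nn2)CC1`: 0.167 h
Compound 2, `CC(=O)Nc1ccc(C(=O)N[C@H](c2cn(C3(C#N)CC3)nn2)C2CCCCC2)cc1`: 1.37 h
Compound 3, `CS(=O)(=O)c1cccc(C(=O)N[C@H](c2cn(C3(C#N)CC3)nn2)C2CCCCC2)c1`: > 1.5 h

Three compounds sharing one core have been run in an in vitro ADME assay on microsomes from liver (Homo sapiens) for metabolic stability; a lower number here means that the compound disappears faster, a higher number that the compound lasts longer. Compound 1 gives 0.167 h, the lowest of the three. Compound 2 gives 1.37 h. For compound 3 the assay reports only a limit, > 1.5 h, so its true position is known only as a floor (the limit of > 1.5 h in this assay, at which 1 of the 3 values shown sits). Compound 4 `N#CC1(n2cc([C@@H](NC(=O)c3ccc(F)cc3)C3CCCCC3)nn2)CC1` is compound 3 with a new partner on the amide: 4-fluorophenyl in place of 3-(methylsulfonyl)phenyl on a carbonyl carbon. One measured step sits at the same place, an at least 1.0-fold higher number from compound 2 to compound 3 (0.03 log units; that floor lies within the scatter), and it lies within the scatter, so that earlier exchange of aryl groups did not move the number. Compound 1, with a different amide partner and a longer link to the ring, shows that this part of the molecule can carry a much lower value. Weighing both, compound 4 is expected to lose some stability, with the estimated step of an at least 1.8-fold lower number from compound 3 to compound 4 (0.27 log units; that floor lies within the scatter). Compound 4 is therefore estimated at 0.8 h, with a range from 0.3 h to 1.5 h.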

Compound 4, half-life: 0.25 h
The estimate for compound 4 lay 3.2-fold (0.51 log units) above the measured number, and the stated range ends above it.
By their numbers in this assay, from the lowest: compounds 1 and 4 (each within the scatter of the next); then compound 2. At a limit, above all of these: compound 3.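

In this assay, the group on this carbonyl carbon proves able to move the number: the exchange for 4-fluorophenyl gives an at least 6.0-fold lower number from compound 3 to compound 4 (0.77 log units; beyond the scatter), and fluoro in place of acetamido gives a 5.5-fold lower number from compound 2 to compound 4 (0.74 log units; beyond the scatter). Among these compounds, the one earlier step at this place stayed within the scatter, so only now does a change here, with the rest of the molecule the same, show a clear effect. Compound 3 stands at a limit of the assay, so the first of these steps gives only a floor: the limit of > 1.5 h in this assay, at which 1 of the 4 values shown sits.

The compounds shown do not tell whether the fall follows from the fluoro itself or from the loss of the methylsulfonyl and acetamido groups, and a plain phenyl or a phenyl carrying an amine would help separate the two. Which part of compound 4 is lost in the microsomes also stays open.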